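Aryl ether variation on the thiazolidinedione series

A few compounds are considered here, and "the series" means these few. Any claim that something is new, unique, unknown or untested is made for them only; others in the source may bear on it.

Measured compounds in a functional assay for agonist activity at Free fatty acid receptor 1 (Homo sapiens), read by FLIPR, in the presence of a further agent that is not named here; a lower number here means that less compound is needed, a higher number that more compound is needed for the effect:
- compound 1 `O=C1NC(=O)C(Cc2ccc(Oc3ncc(Cl)cc3Cl)cc2)S1`: 90 nM
- compound 2 `O=C1NC(=O)C(Cc2ccc(Oc3ccc(C(F)(F)F)cn3)cc2)S1`: 558 nM
- compound 3 `Cc1ccc(Oc2ccc(CC3SC(=O)NC3=O)cc2)nc1`: 4470 nM

Compound 3 stands at the highest number of the three in this assay; its nearest neighbour is compound 2 and the furthest is compound 1, both lying at lower numbers by margins beyond the scatter. Among the compounds with values here, the one step that can be read directly is an 8.0-fold higher number from compound 2 to compound 3 (0.90 log units; beyond the scatter), which shows that exchanging a halogenated substituent for methyl on the pyridinyl ring moves the number up.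

Compound 4 `O=C1NC(=O)C(Cc2ccc(Oc3ccccc3Cl)cc2)S1` differs from compound 3 by 2-chlorophenyl in place of 5-methylpyridin-2-yl on an oxygen on an aromatic ring. Within the data shown here, no measured pair covers exactly this exchange, so only an indirect reading is possible. Among the measured compounds shown here, compound 1, which carries two chlorines on its heteroaryl ring, gives 90 nM, the lowest number in the set, while the methyl-bearing compound 3 gives 4470 nM; together with the step from compound 2 to compound 3 this suggests that returning to a chlorinated ring should bring the number down again, although the change from a pyridinyl to a phenyl ring has no precedent here and widens the uncertainty.

Compound 4 is therefore expected to show a step of a 7.5-fold lower number from compound 3 to compound 4 (0.87 log units; beyond the scatter) in this assay. The estimate for compound 4 is 600 nM, with a range from 150 nM to 2500 nM.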

Compound 4, half-maximal effective concentration: 1190 nM
Estimate against measurement, compound 4: 2.0-fold (0.30 log units) below, and the stated range covers the measured number.
By their numbers in this assay, from the lowest: compound 1; then compound 2; then compound 4; then compound 3.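

In this assay, the step to a ring of carbon only gives a 3.8-fold lower number from compound 3 to compound 4 (0.57 log units; beyond the scatter), so a ring nitrogen in the aryl group on this oxygen is not required for a lower number than that of the methyl-bearing pyridine. Within the data shown here, this is the first reading of a group with no ring nitrogen and no hydrogen-bond acceptor at this place, and it shows that the place tolerates that exchange, with compound 2 at 558 nM and compound 4 at 1190 nM as the printed values for the two groups. No supporting measurement bears on why the number falls with this exchange.

The step changes the ring and its substituent at once, so the compounds shown leave open how much of it belongs to the chlorine and how much to the loss of the ring nitrogen; an unsubstituted phenyl group on the same oxygen would help separate the two. Also open, from the compounds shown here alone, is whether the trend seen with halogenated rings extends to other substituents on a phenyl ring, such as a nitrile or a methoxy group.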